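Capping the amine: acetyl for hydroxyethyl in compound 4

This account rests on a few compounds, and the source may have more. Where it says the series, first, only, none or still open, it means among the compounds named here.

Measured compounds:
compound 1 `Cn1nc2c(=O)n(CC3(O)CCN(Cc4ccc(-c5ccco5)cc4Cl)CC3)cnc2c1-c1ccc(CNCCO)cc1`, 8.2 nM
compound 2 `Cn1nc2c(=O)n(CC3(O)CCN(Cc4ccc(-n5ccnc5)cc4Cl)CC3)cnc2c1-c1ccc(CN)cc1`, 228 nM
compound 3 `Cn1nc2c(=O)n(CC3(O)CCN(Cc4ccc(C5=CCCC5)cc4Cl)CC3)cnc2c1-c1ccc(CN)cc1`, 76.9 nM

All three were tested in an assay on isolated protein for inhibition of ubiquitin carboxyl-terminal hydrolase 7 (Homo sapiens), with stated times of 30 min and 2 h; a higher number here means a weaker inhibitor, a lower number a stronger inhibitor. Compound 1 gives the lowest number of the three; compound 3 is nearest and compound 2 furthest, both gaps beyond the scatter. Among the compounds with values here, the only single-point step among the measured compounds, a 3.0-fold lower number from compound 2 to compound 3 (0.47 log units; beyond the scatter), alters a group on an aromatic carbon elsewhere in the molecule and does not touch the amine arm. Compound 4 `CC(=O)NCc1ccc(-c2c3ncn(CC4(O)CCN(Cc5ccc(-c6ccco6)cc5Cl)CC4)c(=O)c3nn2C)cc1` differs from compound 1 by acetyl in place of 2-hydroxyethyl on an amine nitrogen. Within the data shown here, no measured pair covers this change; compounds 2 and 3 carry a different, uncapped amine and give no guide to acylating the nitrogen. A modest weakening is therefore expected, a 2.4-fold higher number from compound 1 to compound 4 (0.39 log units; beyond the scatter), close to the scatter. Compound 4 is expected to give 20 nM, within 7 nM to 60 nM.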

Compound 4, half-maximal inhibitory concentration: 46.1 nM
The estimate for compound 4 lay 2.3-fold (0.36 log units) below the measured number; measured number inside the range.
By their numbers in this assay, from the lowest: compound 1; then compounds 4 and 3 (each within the scatter of the next); then compound 2.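

Acetyl in place of 2-hydroxyethyl on this amine nitrogen gives a 5.6-fold higher number from compound 1 to compound 4 (0.75 log units; beyond the scatter) and is the first reading at this position. The two groups have the same heavy-atom count, yet the number moves beyond the scatter, so this position responds to a change that swaps 1 hydrogen-bond donor for none and adds a double bond. Nothing available explains the shift. Which of those differences matters remains open. So does how an ethyl or a 2-methoxyethyl group on this nitrogen would compare on the core of compound 1.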